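Replacing 4-methylphenyl with 3-chlorophenyl on a shared core

The source may report more compounds than this note shows. Statements on the series, on what has been measured and on what is new or still open speak of the compounds shown alone.

Compound 1 `O=C1Nc2ccc(F)cc2C1=Cc1ccc(-c2cn(-c3ccccc3)nn2)cc1` gives 11100 nM
Compound 2 `Cc1ccc(-n2cc(-c3ccc(/C=C4\C(=O)Nc5ccc(F)cc54)cc3)nn2)cc1` gives 34600 nM

In a functional assay on MKN-45 cells (Homo sapiens) for inhibition, read by CCK-8 assay, with a stated time of 24 h (on this read-out lower numbers stand for stronger inhibition and higher numbers for weaker inhibition), compound 2 stands highest of the two (at 34600 nM), and its gap to compound 1 lies beyond the scatter. Compound 3 (`O=C1Nc2ccc(F)cc2/C1=C/c1ccc(-c2cn(-c3cccc(Cl)c3)nn2)cc1`) differs from compound 2 by one change: 3-chlorophenyl in place of 4-methylphenyl on an aromatic nitrogen. Among the compounds with values here, no measured pair shows this swap alone, so the forecast is uncertain. Within the data shown here, the only other guide is the lower value of compound 1 (11100 nM). A moderate drop is expected in this assay (estimated as a 2.2-fold lower number from compound 2 to compound 3 (0.33 log units; beyond the scatter)). Compound 3 is expected at 16000 nM (range 6000 nM to 42000 nM).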

Compound 3, half-maximal inhibitory concentration: 14100 nM
Estimate against measurement, compound 3: 1.1-fold (0.05 log units) above; low and high end bracket the measured number.
By their numbers in this assay, from the lowest: compounds 1 and 3 (each within the scatter of the next); then compound 2.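

Swapping 4-methylphenyl for 3-chlorophenyl on the aromatic nitrogen gives a 2.5-fold lower number from compound 2 to compound 3 (0.39 log units; beyond the scatter) in this assay, so this position responds to the choice of phenyl substituent. Compound 1 at 11100 nM and compound 3 at 14100 nM lie within the scatter of each other, so the 3-chloro group shows no gain over plain phenyl. No measured evidence here explains the step.

Open, from the compounds shown here alone, is whether 3-methylphenyl or 4-chlorophenyl would separate the effect of the group from that of its place on the ring. Going by these compounds, how an amine or a carboxylic acid on that ring would read is also open.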